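Compound 3: 3-ethoxyphenyl on the shared core

The compounds below may be only part of what the source reports. "The series", "measured", "known", "first", "only" and "open" are said of these compounds alone.

In a functional assay on HL-60 cells (Homo sapiens) for inhibition, read by MTT assay, with a stated time of 72 h (on this read-out higher numbers stand for weaker inhibition and lower numbers for stronger inhibition), compound 2 (`Cc1nc(-c2ccccc2)c(C(=O)N2CCN(c3ccc(C(F)(F)F)cc3)CC2)o1`) gives > 1000 nM, which is a limit and not a number. Compound 1 (`Cc1nc(-c2ccccc2)c(C(=O)N2CCN(c3cccc(C(N)=O)c3)CC2)o1`) gives 71 nM in this assay. Compound 3 (`CCOc1cccc(N2CCN(C(=O)c3oc(C)nc3-c3ccccc3)CC2)c1`) carries 3-ethoxyphenyl in place of 4-(trifluoromethyl)phenyl on an amine nitrogen in a ring. Among the measured compounds shown here, only one measured step bears on this change: the large at least 14-fold higher number from compound 1 to compound 2 (1.14 log units; beyond the scatter), where 4-(trifluoromethyl)phenyl replaced 3-carbamoylphenyl. Going by that step, a partial return toward lower numbers is expected, an estimated at least 2.8-fold lower number from compound 2 to compound 3 (0.45 log units; beyond the scatter). For compound 3 the expected value is 350 nM, with an estimated range of 70 nM to 1500 nM.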

Compound 3, half-maximal inhibitory concentration: 151 nM
Beside the measured number, compound 3's estimate is 2.3-fold (0.37 log units) above it; the range from low to high includes it.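

Among the compounds shown here, compound 3 shows that carbamoyl is not the only group that keeps the number low on this aromatic carbon: ethoxy in its place gives a 2.1-fold higher number from compound 1 to compound 3 (0.33 log units; beyond the scatter) in this assay, a modest loss. On these data alone, replacing 4-(trifluoromethyl)phenyl with 3-ethoxyphenyl gives an at least 6.6-fold lower number from compound 2 to compound 3 (0.82 log units; beyond the scatter), whose full size remains unknown. Compound 2 gives a limit, not a number: the limit of > 1000 nM in this assay, at which 1 of the 3 values shown sits.

Open, as far as these compounds go, is whether the group or its place on the ring drives this step, which 3-(trifluoromethyl)phenyl and 4-ethoxyphenyl would separate. Also open, from the compounds shown here alone, is how a carboxylic acid or a propoxy chain would read here.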